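The source may hold more compounds than are shown below. What is called first, only, known or untested is meant among the compounds shown, and "the series" means these compounds.

Working notes on the chalcone-bearing series. Compound 1 `O=C(/C=C/c1cccc(O)c1)c1cccc(-n2cc(-c3ccccc3)[nH]c2=O)c1` and compound 2 `COc1cc(/C=C/C(=O)c2cccc(-n3cc(-c4ccccc4)[nH]c3=O)c2)cc(OC)c1OC` share one core and differ in the substitution of the cinnamoyl aryl ring. In a functional assay on COLO 205 cells (Homo sapiens) for inhibition (on this read-out lower numbers stand for stronger inhibition of growth and higher numbers for weaker inhibition of growth), compound 1 gives 2010 nM and compound 2 gives 1510 nM. Compound 2 holds the lowest of the two numbers, but its gap to compound 1 lies within the usual scatter of this assay, so the two values cannot be told apart.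

The next compound is compound 3 `COc1cc(/C=C/C(=O)c2cccc(-n3cc(-c4cc(OC)c(OC)c(OC)c4)[nH]c3=O)c2)cc(OC)c1OC`. It differs from compound 2 in one place: 3,4,5-trimethoxyphenyl in place of phenyl on an aromatic carbon. Among the measured compounds shown here, no pair of measured compounds differs by this change, so nothing in this assay shows its size or direction; the expected step is none beyond the scatter. Compound 3 is therefore estimated at 1500 nM, with a range from 500 nM to 4500 nM, which means an expected step of a 1.0-fold lower number from compound 2 to compound 3 (0.00 log units; within the scatter).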

Compound 3, concentration for 50% growth inhibition: 1520 nM
Compound 3: the middle estimate sits 1.0-fold (0.01 log units) below what was measured; the measured number falls inside the stated range.
By their numbers in this assay, from the lowest: compounds 2, 3 and 1 (each within the scatter of the next).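

In this assay the step is a 1.0-fold higher number from compound 2 to compound 3 (0.00 log units; within the scatter), so on this aromatic carbon of the five-membered ring, next to the ring nitrogen, 3,4,5-trimethoxyphenyl in place of phenyl produces no change that can be read. The earlier compounds shown here carried only phenyl here and gave no reading at this position; it now accepts a group of 12 heavy atoms with 3 hydrogen-bond acceptors in place of one of 6 heavy atoms with none, and the number stays within the scatter. Nothing available accounts for this result.

On these data alone, it remains open whether an amine or a carboxylic acid at this position would move the number. As far as these compounds go, it is also open whether the same change would give the same result on the core of compound 1, with its different cinnamoyl aryl ring.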